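Formyl for ethyl in a two-compound inhibition series

The source may report more compounds than this note shows. Statements on the series, on what has been measured and on what is new or still open speak of the compounds shown alone.

Of the compounds shown here, two have been measured in a functional assay on DU-145 cells (Homo sapiens) for inhibition, read by sulforhodamine B assay, with a stated time of 48 h, tested at 10 uM; a lower number here means less inhibition, a higher number more inhibition at the concentration tested (going by the name of the read-out). Compound 1 `Brc1cn2ccnc2c(-c2ccc3ncn(C4CCCCC4)c3c2)n1` gives 6.2% in this assay. Compound 2 `CCc1ccc(-c2cn3ccnc3c(-c3ccc4ncn(Cc5ccccc5)c4c3)n2)cc1` gives 19.1% in this assay, the higher of the two numbers, with compound 1 lying beyond the scatter below it. Among the compounds with values here, the two compounds differ in more than one place, so no single step links them. Compound 3 `O=Cc1ccc(-c2cn3ccnc3c(-c3ccc4ncn(Cc5ccccc5)c4c3)n2)cc1` carries the change (formyl in place of ethyl on an aromatic carbon). Within the data shown here, no measured pair shows what this swap does, so the step from compound 2 to compound 3 is expected to stay within the scatter, with the number about level: a number 1.1 percentage points lower from compound 2 to compound 3 (within the scatter). Compound 3 is thus expected to give 18% in this assay, within 5% to 35%.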

Compound 3, a percentage reported as inhibition, at one concentration (the size of the read-out at that concentration, not a potency): 24.3%
For compound 3 the middle estimate is 6.3 percentage points below the measured one; low and high end bracket the measured number.
By their numbers in this assay, from the lowest: compound 1; then compounds 2 and 3 (each within the scatter of the next).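

In this assay, within the data shown here, the only single-place step puts formyl in place of ethyl on an aromatic carbon (a number 5.2 percentage points higher from compound 2 to compound 3 (within the scatter)). This position, para to a large group, thus takes 4-formylphenyl in place of 4-ethylphenyl, adding a hydrogen-bond acceptor, without a shift beyond the scatter in this pair. No measurement shown bears on why the number stays there. On these data alone, whether an amine, a carboxylic acid or a longer chain at this position would move the number remains open. So does whether the swap would read the same on any compound other than this pair.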